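Compound 3 to compound 4: trifluoromethyl for carbamoyl

The source may hold more compounds than are shown below. What is called first, only, known or untested is meant among the compounds shown, and "the series" means these compounds.

Compound 1 `Cc1cc(NC(=O)Nc2ccccc2N)c2ccccc2n1` gives > 25000 nM in an ADME assay on HEK293 cells (Homo sapiens) for cytotoxicity, with a stated time of 72 h (a higher number here means that more compound is needed for the effect, a lower number that less compound is needed), and this is a limit. Compound 2 `Cc1cc(NC(=O)Nc2ccccc2C(C)(C)C)c2ccccc2n1` gives > 25000 nM in this assay, again a limit. Compound 3 `Cc1cc(NC(=O)Nc2ccccc2C(N)=O)c2ccccc2n1` gives > 25000 nM in this assay, also a limit, so it has no number of its own. Among the compounds with values here, the series so far stands at the limit of > 25000 nM in this assay, at which 3 of the 3 values shown sit.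

Compound 4 `Cc1cc(NC(=O)Nc2ccccc2C(F)(F)F)c2ccccc2n1` carries trifluoromethyl in place of carbamoyl on an aromatic carbon, and the change counts as follows: trifluoromethyl in place of carbamoyl on an aromatic carbon.

Within the data shown here, three measured steps concern the same place: a step that the two limits leave unreadable from compound 1 to compound 2, a step that the two limits leave unreadable from compound 1 to compound 3 and a step that the two limits leave unreadable from compound 2 to compound 3. None of them gives a size. Amino, tert-butyl and carbamoyl all leave the reading at the limit, and this is the only guide to the new group. In this assay the expected outcome is another limit, with no step beyond the scatter in either direction. The estimated change is a step that the limit leaves unreadable from compound 3 to compound 4. For compound 4 the estimated value is 30000 nM, with an expected range from 15000 nM to 50000 nM.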

Compound 4, half-maximal effective concentration: > 25000 nM
Compound 4: only a limit was reported; the forecaster's own chance of this, stated with the estimate: 85%; the middle value is on the limit's open side.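

Within the data shown here, compound 4 stays at a limit like compounds 1, 2 and 3, so no step from any of them to compound 4 can be read in this assay: the limit of > 25000 nM in this assay, at which 4 of the 4 values shown sit. The compounds shown leave open whether any group at this place would give a measurable value in this assay.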